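From pyrrolyl to chlorophenyl: a step in growth inhibition

A few compounds are considered here, and "the series" means these few. Any claim that something is new, unique, unknown or untested is made for them only; others in the source may bear on it.

Compound 1 `N#C/C(=C\c1ccc[nH]1)C(=O)NCc1ccc(Cl)c(Cl)c1`: > 50000 nM
Compound 2 `COc1ccc(CNC(=O)/C(C#N)=C/c2ccco2)cc1`: 34000 nM

In a functional assay on MIA cells (Homo sapiens) for inhibition, read by MTT assay, with a stated time of 72 h (a higher number here means a weaker inhibitor of growth, a lower number a stronger inhibitor of growth), compound 1 sits at the limit of > 50000 nM in this assay, at which 1 of the 2 values shown sits, a limit of the assay rather than a number. Compound 2 gives 34000 nM in this assay. Compound 3 `N#C/C(=C\c1ccc(Cl)cc1)C(=O)NCc1ccc(Cl)c(Cl)c1` differs from compound 1 by 4-chlorophenyl in place of 1H-pyrrol-2-yl on a double-bonded chain carbon bound to a double-bonded chain carbon. Going by the values given here, no measured step joins these two, and both measured compounds are weak, so no shift beyond the scatter is expected in either direction. Compound 3 is therefore estimated at 35000 nM, within 8000 nM to 100000 nM, meaning an expected step of an at least 1.4-fold lower number from compound 1 to compound 3 (0.15 log units; that floor lies within the scatter).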

Compound 3, concentration for 50% growth inhibition: 31000 nM
The estimate for compound 3 lay 1.1-fold (0.05 log units) above the measured number, within the range that was stated.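

Putting 4-chlorophenyl in place of 1H-pyrrol-2-yl gives an at least 1.6-fold lower number from compound 1 to compound 3 (0.20 log units; that floor lies within the scatter) in this assay and yields a readable number at this position, on a double-bonded chain carbon bound to a double-bonded chain carbon. Compound 1 remains a limit of the assay, not a number: the limit of > 50000 nM in this assay, at which 1 of the 3 values shown sits. The true size of the step is therefore unknown, and a carbon-only aromatic ring without a hydrogen-bond donor leaves growth inhibition weak here.

This single change cannot separate the loss of the pyrrole nitrogen from the entry of chlorine. From the compounds shown here alone, how an unsubstituted phenyl, or a phenyl carrying an amine or a carboxylic acid, would read at this position remains open.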